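Shifting the Carboxylic Acid Around the Pyridine Ring

The source may hold more compounds than are shown below. What is called first, only, known or untested is meant among the compounds shown, and "the series" means these compounds.

Compound 1 `Fc1cnc(Nc2cc3[nH]c(-c4cccc(C(F)(F)F)c4)nc3cn2)c(F)c1`: in a physicochemical assay for solubility, using the shake flask method, in simulated intestinal fluid, measured as kinetic solubility, with a stated time of 20 h, at pH 6.5 (on this read-out higher numbers stand for higher solubility and lower numbers for lower solubility), compound 1 sits at the limit of >= 50000 nM.
Compound 2 `O=C(O)c1ccc(Nc2cc3[nH]c(-c4cccc(C(F)(F)F)c4)nc3cn2)nc1`: in this assay compound 2 gives 6000 nM.

Among the measured compounds shown here, compound 2 is the only compound of the pair with a number rather than a limit, and it gives the lower value of the two in this assay. For the measured compounds named here, the single measured step, an at least 8.3-fold lower number from compound 1 to compound 2 (0.92 log units; beyond the scatter), runs from a value that is only known as a limit, (the limit of >= 50000 nM in this assay, at which 1 of the 2 values shown sits), so its true size is open at the upper end.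

Compound 3 `O=C(O)c1ccnc(Nc2cc3[nH]c(-c4cccc(C(F)(F)F)c4)nc3cn2)c1` is the unmeasured isomer, differing from compound 2 only in where the acid sits: 4-carboxypyridin-2-yl in place of 5-carboxypyridin-2-yl on a nitrogen on an aromatic ring. Going by the values given here, no measured step addresses this kind of change; the one step on record exchanges the whole pyridine substituent and rests on a limit, so it gives no direction for a move of the acid within the same ring. The expected step is therefore no change at the digits printed from compound 2 to compound 3 (within the scatter), a change that is not expected to go beyond the scatter. Compound 3 is estimated to give 6000 nM in this assay, with a range from 2000 nM to 20000 nM.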

Compound 3, solubility: 60000 nM
Estimate against measurement, compound 3: 10-fold (1.00 log units) below; measured number above the stated range.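

Moving the carboxylic acid within one pyridine ring, with the same atoms joined differently, gives a 10-fold higher number from compound 2 to compound 3 (1.00 log units; beyond the scatter) in this assay. Among the compounds shown here, this is the first step on record with a number at both ends, and the first to isolate the place of the acid on the ring, since the step from compound 1 to compound 2 exchanged the whole pyridine substituent and started from a limit. So at this nitrogen-linked position, 4-carboxypyridin-2-yl and 5-carboxypyridin-2-yl cannot be treated as interchangeable, while compound 1 remains a limit and its step to compound 3 cannot be read: the limit of >= 50000 nM in this assay, at which 1 of the 3 values shown sits.

The compounds shown give no measured property that would account for the difference between the two isomers, so its cause stays open. Also open, going by these compounds, is whether the same dependence on ring placement would hold for another group on the pyridine ring, such as an amine or a carboxamide in place of the carboxylic acid, or whether it belongs to the acid alone.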